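A few compounds are considered here, and "the series" means these few. Any claim that something is new, unique, unknown or untested is made for them only; others in the source may bear on it.

Measured in a functional assay on MDA-MB-231 cells (Homo sapiens) for cytotoxicity, read by MTT assay, with a stated time of 48 h (a lower number here means a stronger inhibitor, a higher number a weaker inhibitor), are three compounds:
compound 1 `COc1cc(/C=C/c2ccc(OCCCC(=O)NO)cc2)cc(OC)c1` gives 3890 nM
compound 2 `COc1cc(/C=C/c2ccc(OCCCCC(=O)NO)cc2)cc(OC)c1` gives 4210 nM
compound 3 `COc1cc(/C=C/c2ccc(OCCCCCCC(=O)NO)cc2)cc(OC)c1` gives 780 nM

Compound 1 sits level with compound 2 within the scatter, and both stand above compound 3. Compound 4 `COc1cc(/C=C/c2ccc(OCc3cccc(C(=O)NO)c3)cc2)cc(OC)c1` keeps the core of compound 1 and differs thus: 3-(hydroxycarbamoyl)phenyl in place of 2-(hydroxycarbamoyl)ethyl on a saturated chain carbon bound to an oxygen on an aromatic ring with 3-(hydroxycarbamoyl)phenyl in place of 2-(hydroxycarbamoyl)ethyl on a saturated chain carbon bound to an oxygen on an aromatic ring. Only chain steps bear on this, and only indirectly. They are a 1.1-fold higher number from compound 1 to compound 2 (0.03 log units; within the scatter) and a 5.4-fold lower number from compound 2 to compound 3 (0.73 log units; beyond the scatter) and also a 5.0-fold lower number from compound 1 to compound 3 (0.70 log units; beyond the scatter) but none of them tests a ring in the chain. A modest step to a lower number is therefore expected in this assay with wide uncertainty. The estimated change is a 2.6-fold lower number from compound 1 to compound 4 (0.41 log units; beyond the scatter) in this read-out. For compound 4 the expected value is 1500 nM with an estimated range from 400 nM to 5000 nM overall.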

Compound 4, half-maximal inhibitory concentration: 9220 nM
Estimate against measurement, compound 4: 6.1-fold (0.79 log units) below, and the stated range ends below it.
By their numbers in this assay, from the lowest: compound 3; then compounds 1 and 2 (each within the scatter of the next); then compound 4.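

Putting 3-(hydroxycarbamoyl)phenyl in place of the chain on the saturated chain carbon bound to an oxygen on an aromatic ring raises the number against all three chain compounds: the steps are (a 2.4-fold higher number from compound 1 to compound 4 (0.37 log units; beyond the scatter)) and (a 2.2-fold higher number from compound 2 to compound 4 (0.34 log units; beyond the scatter)) and (a 12-fold higher number from compound 3 to compound 4 (1.07 log units; beyond the scatter)). Going by these compounds alone, the earlier compounds showed only that chain length could leave the number level or lower it, whereas this ring-bearing group gives the highest number of the set, and the largest gap is to compound 3. Nothing measured here accounts for this result. Open, on these data alone, is whether a longer chain than that of compound 3 would lower the number further. Also open, as far as these compounds go, is how a saturated chain placed between the ring and the hydroxycarbamoyl group would compare with compound 4.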